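Methylsulfonyl on the pyrazole nitrogen of compound 3

The source may report more compounds than this note shows. Statements on the series, on what has been measured and on what is new or still open speak of the compounds shown alone.

Compound 3 `CNC(=O)N1CCCc2ccc(NC(=O)c3ccc(-c4cn[nH]c4)cc3)cc21` stands highest of the three numbers in a functional assay on MV4-11 cells (Homo sapiens) for antiproliferative activity, with a stated time of 6 days, tested at 6.25 uM (on this read-out higher numbers stand for a stronger effect at the one concentration tested and lower numbers for a weaker effect), where compound 3 gives 98.3%; compound 1 `CNC(=O)N1CCCc2ccc(NC(=O)c3ccc(-c4ccncc4)cc3)cc21` is nearest, giving 88.7%, with a number 9.6 percentage points higher from compound 1 to compound 3 (within the scatter), and compound 2 `CNC(=O)N1CCCc2ccc(NC(=O)c3ccc(-c4ccn(S(C)(=O)=O)n4)cc3)cc21` furthest, giving 57.2%, with a number 41.1 percentage points higher from compound 2 to compound 3 (beyond the scatter). Compound 4 `CNC(=O)N1CCCc2ccc(NC(=O)c3ccc(-c4cnn(S(C)(=O)=O)c4)cc3)cc21` differs from compound 3 by methylsulfonyl in place of hydrogen on an aromatic nitrogen. For the measured compounds named here, the steps that bear on this change both involve the methylsulfonyl pyrazole of compound 2: a number 31.5 percentage points lower from compound 1 to compound 2 (beyond the scatter) and a number 41.1 percentage points higher from compound 2 to compound 3 (beyond the scatter), each large. A drop beyond the scatter is therefore expected for compound 4, though the attachment of the pyrazole differs from that in compound 2, so the size is uncertain. Compound 4 is estimated at 65%, within 40% to 90%, an expected step of a number 33.3 percentage points lower from compound 3 to compound 4 (beyond the scatter).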

Compound 4, a percentage reported as inhibition, at one concentration (the size of the read-out at that concentration, not a potency): 40.2%
Beside the measured number, compound 4's estimate is 24.8 percentage points above it, within the range that was stated.
By their numbers in this assay, from the lowest: compound 4; then compound 2; then compounds 1 and 3 (each within the scatter of the next).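

In this assay, methylsulfonyl in place of hydrogen on the aromatic nitrogen of the 1H-pyrazol-4-yl group was now seen directly to lower the number, with a number 58.1 percentage points lower from compound 3 to compound 4 (beyond the scatter). The 1-(methylsulfonyl)-1H-pyrazol-4-yl group did not do better than its 1-(methylsulfonyl)-1H-pyrazol-3-yl counterpart, with a number 17 percentage points lower from compound 2 to compound 4 (beyond the scatter), and against pyridin-4-yl the step was a number 48.5 percentage points lower from compound 1 to compound 4 (beyond the scatter). No measurement at hand accounts for this loss. Going by these compounds, whether methyl or a 2-hydroxyethyl chain on that nitrogen would keep the number near that of compound 3 remains open, as does whether the loss is specific to methylsulfonyl.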